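This account rests on a few compounds, and the source may have more. Where it says the series, first, only, none or still open, it means among the compounds named here.

Measured compounds:
compound 1 `O=c1oc2ccccc2c2nc3c(ccc4cc[nH]c43)c(-c3ccc(C(F)(F)F)cc3)c12`, 70700 nM
compound 2 `O=c1oc2ccccc2c2nc3c(ccc4cc[nH]c43)c(-c3ccc([N+](=O)[O-])cc3)c12`, 70700 nM

In a functional assay on B16-F10 cells (Mus musculus) for cytotoxicity (a higher number here means a weaker inhibitor, a lower number a stronger inhibitor), compound 1 gives 70700 nM and compound 2 gives 70700 nM; compound 1 stands level with compound 2 at the digits shown. Within the data shown here, the only measured step, no change at the digits printed from compound 1 to compound 2 (within the scatter), lies within the scatter. Compound 3 `O=c1oc2ccccc2c2nc3c(ccc4cc[nH]c43)c(-c3ccccc3Br)c12` differs from compound 1 by 2-bromophenyl in place of 4-(trifluoromethyl)phenyl on an aromatic carbon. Among the measured compounds shown here, no measured step covers a 2-bromophenyl, so no change at the digits printed from compound 1 to compound 2 (within the scatter) bears on it only loosely, and no step beyond the scatter is expected in this assay. Compound 3 is expected to give about 70000 nM, within 25000 nM to 150000 nM. The expected step is a 1.0-fold lower number from compound 1 to compound 3 (0.00 log units; within the scatter).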

Compound 3, half-maximal inhibitory concentration: 70700 nM
Compound 3: the middle estimate sits 1.0-fold (0.00 log units) below what was measured; low and high end bracket the measured number.
By their numbers in this assay, from the lowest: compounds 1, 2 and 3 (each within the scatter of the next).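

In this assay, 2-bromophenyl in place of 4-(trifluoromethyl)phenyl gives no change at the digits printed from compound 1 to compound 3 (within the scatter), and 2-bromophenyl in place of 4-nitrophenyl gives no change at the digits printed from compound 2 to compound 3 (within the scatter). The earlier pair covered only 4-substituted phenyl groups, whereas these steps extend the flat result at this position, opposite the ring nitrogen, to a 2-substituted phenyl bearing bromine. No supporting data on any cause accompany this result.

Open, as far as these compounds go, is whether a group other than a substituted phenyl at this position, such as a primary amine, a carboxylic acid or a longer alkyl chain, would shift the number in this assay. Also open, from the compounds shown here alone, is how 4-bromophenyl compares with 2-bromophenyl on the same core.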